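The compounds below may be only part of what the source reports. "The series", "measured", "known", "first", "only" and "open" are said of these compounds alone.

Compound 1 `Cc1ccc(NC(=O)CCN(Cc2ccc(C(=O)NO)cc2)C(=O)c2cc(C)cc(C)c2)cc1` is the reference point here: in a functional assay on G55T2 cells (Homo sapiens) for antiproliferative activity, read by WST assay, with a stated time of 72 h (on this read-out lower numbers stand for stronger inhibition and higher numbers for weaker inhibition), compound 1 gives 370 nM. Among the measured compounds shown here, compound 2 `Cc1cc(C)cc(C(=O)N(CCC(=O)NCc2ccccc2)Cc2ccc(C(=O)NO)cc2)c1` differs from it in one place, benzyl in place of 4-methylphenyl on an amide-type nitrogen, and the result is an 11-fold higher number from compound 1 to compound 2 (1.06 log units; beyond the scatter), so that compound 2 gives 4250 nM and stands as the highest of the two numbers measured so far.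

Compound 3 `Cc1ccc(C(=O)N(CCC(=O)NCc2ccccc2)Cc2ccc(C(=O)NO)cc2)cc1` is the next step from compound 2. The change is 4-methylphenyl in place of 3,5-dimethylphenyl on a carbonyl carbon. For the measured compounds named here, no measured step touches this carbonyl carbon: the only step available, an 11-fold higher number from compound 1 to compound 2 (1.06 log units; beyond the scatter), alters the amide-type nitrogen side and says nothing about the group on the carbonyl. With no guidance from the measured pair, the step is expected to stay within the scatter, a 1.1-fold lower number from compound 2 to compound 3 (0.03 log units; within the scatter). Compound 3 is therefore estimated at 4000 nM, with a range from 1500 nM to 11000 nM.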

Compound 3, half-maximal inhibitory concentration: 690 nM
Compound 3: the middle estimate sits 5.8-fold (0.76 log units) above what was measured, and the stated range ends above it.
By their numbers in this assay, from the lowest: compounds 1 and 3 (each within the scatter of the next); then compound 2.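

In this assay the group on the carbonyl carbon clearly counts, since replacing 3,5-dimethylphenyl with 4-methylphenyl gives a 6.2-fold lower number from compound 2 to compound 3 (0.79 log units; beyond the scatter) on this read-out. Among the compounds shown here, the earlier pair changed only the amide-type nitrogen side, so this is the first measured sign that the carbonyl side also moves the number, even though the change only takes this group from 8 heavy atoms to 7 and keeps its aromatic ring. No measurement available here explains why this change has such an effect.

Going by these compounds, this step has been read only with benzyl on the amide-type nitrogen, so its size with the 4-methylphenyl of compound 1 in that place remains open. Also open, on these data alone, is how a plain phenyl, 4-chlorophenyl or 4-methoxyphenyl group on the carbonyl carbon would compare with the 4-methylphenyl of compound 3.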